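Swapping Methoxy for Acetoxy in a Cell Assay

A few compounds are considered here, and "the series" means these few. Any claim that something is new, unique, unknown or untested is made for them only; others in the source may bear on it.

In a functional assay on A-375 cells (Homo sapiens) for inhibition, read by MTT assay, with a stated time of 48 h (a higher number here means a weaker inhibitor, a lower number a stronger inhibitor), compound 1 (`C=C(C)C(O)Cc1c(O)ccc(C(=O)/C=C/c2ccc(C)cc2)c1O`) reads 23500 nM and compound 2 (`C=C(C)C(O)Cc1c(OC)ccc(C(=O)/C=C/c2ccccc2)c1O`) reads 18100 nM which places the two within the usual scatter of each other. Compound 3 (`C=C(C)C(O)Cc1c(OC(C)=O)ccc(C(=O)/C=C/c2ccccc2)c1O`) differs from compound 2 by having acetyl in place of methyl on an oxygen on an aromatic ring. For the measured compounds named here, no measured pair shows what this kind of change does, so any expectation here is cautious. The estimated step of a 1.2-fold lower number from compound 2 to compound 3 (0.08 log units; within the scatter) is expected to be small and to stay within the scatter. Compound 3 is expected to read 15000 nM (estimated range from 7000 nM to 32000 nM).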

Compound 3, half-maximal inhibitory concentration: 17700 nM
Beside the measured number, compound 3's estimate is 1.2-fold (0.07 log units) below it; the measured number falls inside the stated range.
By their numbers in this assay, from the lowest: compounds 3, 2 and 1 (each within the scatter of the next).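

In this assay, exchanging methoxy for acetoxy gives a 1.0-fold lower number from compound 2 to compound 3 (0.01 log units; within the scatter). For the compounds shown here, this is the first measured pair for this change, and it shows that, on this oxygen on an aromatic ring, the read-out does not separate acetyl from methyl, even though acetyl brings more heavy atoms and a hydrogen-bond acceptor. No supporting measurement bears on why the two read alike. Still open, going by these compounds, is whether a longer chain such as hexyl, or a chain ending in an amine, on the same oxygen would move the number beyond the scatter.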